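This account rests on a few compounds, and the source may have more. Where it says the series, first, only, none or still open, it means among the compounds named here.

The measured compounds and their values in an assay on isolated protein for inhibition of ubiquitin carboxyl-terminal hydrolase 7 (Homo sapiens), read by fluorescence, with stated times of 30 min and 3 h; on this read-out lower numbers stand for stronger inhibition and higher numbers for weaker inhibition:

Compound 1, `O=C(Nc1ccccc1)c1nc([N+](=O)[O-])c(Sc2c(Cl)cncc2Cl)s1`, gives 40500 nM.
Compound 2, `CC(=O)c1nc([N+](=O)[O-])c(Sc2ccc(Cl)cc2Cl)s1`, gives 16800 nM.
Compound 3, `CC(=O)c1nc([N+](=O)[O-])c(NCc2ccc(Cl)c(Cl)c2)s1`, reports only the assay limit, > 50000 nM.

Among the two compounds with a number, compound 1 holds the higher one, and the gap down to compound 2 lies beyond the usual scatter. Compound 3 sits at the limit of > 50000 nM in this assay, at which 1 of the 3 values shown sits, so it contributes no number of its own. For the measured compounds named here, no pair among the three differs in a single place, so no single step can be read from the measured set; compound 1 and compound 2 differ in more than one part of the structure, and their two values only show that compound 2 stands lower.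

The unmeasured compound 4, `Cc1ccc(CNC(=O)c2nc([N+](=O)[O-])c(Sc3c(Cl)cncc3Cl)s2)cc1`, differs from compound 1 in one place: 4-methylbenzyl in place of phenyl on an amide-type nitrogen. Everything else in compound 1 is kept. Going by the values given here, with no measured step of this kind to lean on, the expectation rests on compound 1 alone. The step of a 1.6-fold lower number from compound 1 to compound 4 (0.21 log units; within the scatter) is expected to be small, with a slight lean toward a lower number but not clearly beyond the scatter. On that basis compound 4 is estimated at 25000 nM, with a range from 8000 nM to 80000 nM.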

Compound 4, half-maximal inhibitory concentration: 3650 nM
Compound 4: the middle estimate sits 6.8-fold (0.84 log units) above what was measured; measured number outside the range, below it.
By their numbers in this assay, from the lowest: compound 4; then compound 2; then compound 1. At a limit, above all of these: compound 3.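

In this assay, for the compounds shown here, the exchange of phenyl for 4-methylbenzyl on the amide-type nitrogen gives an 11-fold lower number from compound 1 to compound 4 (1.05 log units; beyond the scatter), the first single-place step in the set, and it shows that the group at this position has a large bearing on the read-out. The exchange keeps one six-membered aromatic ring of carbon only, adds carbon alone, and leaves the rest of compound 1 as it was, so a change of this limited kind at this one position is enough for a step of this size. The compounds shown give no measured basis for saying why the step is so large.

As far as these compounds go, it remains open whether the step goes with the benzyl part or with the methyl of 4-methylbenzyl: an unsubstituted benzyl group or a longer chain such as phenethyl on the same nitrogen would separate the two. Also open, from the compounds shown here alone, is whether the number moves further when the methyl gives way to a carboxylic acid or an amine.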